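Methoxy for hydrogen: cytotoxicity notes on four compounds

The source may hold more compounds than are shown below. What is called first, only, known or untested is meant among the compounds shown, and "the series" means these compounds.

Compound 1 `N=C(N)c1ccc(-c2cc3ccc(C(=N)N)cc3o2)cc1` and compound 3 `COc1cc(C(=N)N)ccc1-c1cc2ccc(C(=N)N)cc2o1` share a core and differ by one change, (methoxy in place of hydrogen on an aromatic carbon). In an ADME assay on L6 cells (Rattus norvegicus) for cytotoxicity (on this read-out higher numbers stand for weaker inhibition and lower numbers for stronger inhibition), compound 1 gives 800 nM, while compound 3 gives 108000 nM; the step of a 140-fold higher number from compound 1 to compound 3 (2.13 log units; beyond the scatter) is large. Compound 2 `CC(C)NC(=N)c1ccc(-c2cc3ccc(C(=N)NC(C)C)cc3o2)cc1` carries a different core; how the two cores differ is not broken down here. In this assay compound 2 reaches only a limit, > 199000 nM, as noted in the limit of > 199000 nM in this assay, at which 1 of the 3 values shown sits. Compound 4 `COc1cc(C(=N)NC(C)C)ccc1-c1cc2ccc(C(=N)NC(C)C)cc2o1` stands to compound 2 as compound 3 stands to compound 1, through (methoxy in place of hydrogen on an aromatic carbon). The surroundings are not identical: in compound 3 the new group sits meta to a group of 3 heavy atoms, in compound 4 meta to a group of 6 heavy atoms, so this is the same kind of change rather than the same change. With compound 2 already at the limit, compound 4 is expected to sit at or beyond that limit as well, an expected step that the limit leaves unreadable from compound 2 to compound 4 in this assay. The estimate for compound 4 is 400000 nM, within 150000 nM to 1500000 nM, most likely reported only as a limit.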

Compound 4, half-maximal inhibitory concentration: > 181000 nM
Compound 4: no number, only a limit; the forecaster's own chance of this, stated with the estimate: 90%; the middle value lies beyond the limit too.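

Compound 2 and compound 4 both stand only as limits in this assay, so the step between them cannot be read. The compounds shown leave open whether methoxy in place of hydrogen shifts the read-out at all on the core of compound 2, as it does between compound 1 and compound 3.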